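A small group on a weakly active compound

A few compounds are considered here, and "the series" means these few. Any claim that something is new, unique, unknown or untested is made for them only; others in the source may bear on it.

- compound 1 `N#Cc1cccc(NC(=O)c2cc(F)ccc2O)c1`: 7750 nM
- compound 2 `O=C(Nc1ccccc1)c1cc(F)ccc1O`: > 10000 nM (a limit)

In a functional assay on HL-60 cells (Homo sapiens) for cytotoxicity, read by luminescence and CellTiter-Glo, with a stated time of 3 days (a lower number here means a stronger inhibitor, a higher number a weaker inhibitor), compound 2 is known only by a limit, > 10000 nM, and not by a number. Compound 3 `O=C(Nc1cccc(C(F)(F)F)c1)c1cc(F)ccc1O` differs from it by trifluoromethyl in place of hydrogen on an aromatic carbon. Among the measured compounds shown here, the one measured step that bears on this is an at least 1.2-fold higher number from compound 1 to compound 2 (0.11 log units; that floor lies within the scatter), hydrogen in place of cyano on an aromatic carbon. Compound 1, at 7750 nM, keeps a group where compound 2 has hydrogen, so only a modest step to a lower number is expected in this assay. The expected change is an at least 2.0-fold lower number from compound 2 to compound 3 (0.30 log units; that floor lies within the scatter). Compound 3 is estimated at 5000 nM, within an expected range of 1500 nM to 10000 nM.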

Compound 3, half-maximal inhibitory concentration: 970 nM
Estimate against measurement, compound 3: 5.2-fold (0.71 log units) above, and the stated range ends above it.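

Trifluoromethyl in place of hydrogen on this aromatic carbon gives an at least 10-fold lower number from compound 2 to compound 3 (1.01 log units; beyond the scatter) in this assay, so this position can move the number much further than the earlier pair showed. The choice of group matters here, not only the presence of one, with an 8.0-fold lower number from compound 1 to compound 3 (0.90 log units; beyond the scatter) for trifluoromethyl in place of cyano. The step from hydrogen is only a floor, since compound 2 is known by a limit: the limit of > 10000 nM in this assay, at which 1 of the 3 values shown sits.

From the compounds shown here alone, whether an amine, a carboxylic acid or a methoxy group on this carbon would give a lower or higher number stays open. So does whether trifluoromethyl would have a similar effect on another carbon of this ring.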